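The compounds below may be only part of what the source reports. "The series", "measured", "known", "first", "only" and "open" are said of these compounds alone.

Measured compounds:
compound 1, `O=S1(=O)Cc2nc(-c3cc(F)c(Cl)cc3F)nc(N3CCC(CO)CC3)c2C1`, 0.3 mg/kg
compound 2, `NC(=O)C1CCN(c2nc(-c3cc(F)c(Cl)cc3F)nc3c2CS(=O)(=O)C3)CC1`, 3 mg/kg

Both were tested in a functional assay on the whole organism (blood, strain ICR) with Mus musculus as the target, in the glucose tolerance test, with a stated time of 30 min; a higher number here means that more compound is needed for the effect, a lower number that less compound is needed. Compound 1 has the lowest number of the two, and the step of a 10-fold higher number from compound 1 to compound 2 (1.00 log units; beyond the scatter) lies beyond the scatter.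

Compound 3, `O=S1(=O)Cc2nc(-c3cc(F)c(Cl)cc3F)nc(N3CCC(O)CC3)c2C1`, is not yet measured. It differs from compound 1 in one place: hydroxy in place of hydroxymethyl on a saturated ring carbon. Within the data shown here, the only measured step touches the same saturated ring carbon, where carbamoyl in place of hydroxymethyl gave a 10-fold higher number from compound 1 to compound 2 (1.00 log units; beyond the scatter). That step swaps one group for a different one, so it bears on the new change only loosely; a shift of similar size, but a smaller one, is a fair guess, with the risk that the number rises. For compound 3 a step of a 2.0-fold higher number from compound 1 to compound 3 (0.30 log units; within the scatter) is expected, and its value is estimated at 0.6 mg/kg, within a range of 0.15 mg/kg to 3 mg/kg.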

Compound 3, minimum effective dose: 1 mg/kg
The estimate for compound 3 lay 1.7-fold (0.22 log units) below the measured number; low and high end bracket the measured number.
By their numbers in this assay, from the lowest: compound 1; then compound 3; then compound 2.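

With the hydroxy group kept and only the carbon that carried it removed, this assay shows a 3.3-fold higher number from compound 1 to compound 3 (0.52 log units; beyond the scatter) so even this small shortening at the saturated ring carbon counts. The same test gives a 3.0-fold lower number from compound 2 to compound 3 (0.48 log units; beyond the scatter) which places the hydroxy compound apart from the carbamoyl compound as well, and the three groups now rank, from the lowest number, as hydroxymethyl, hydroxy and carbamoyl. The step from hydroxymethyl to hydroxy appears even though both groups have the same printed count of hydrogen-bond donors and acceptors.

As far as these compounds go, whether a longer chain such as hydroxyethyl, an amine or a carboxylic acid at this carbon would lower or raise the number remains open. No measurement shown here explains the differences between these groups.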